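A Sulfone in Place of the Sulfonamide on the Core

A few compounds are considered here, and "the series" means these few. Any claim that something is new, unique, unknown or untested is made for them only; others in the source may bear on it.

Compound 2 (`CS(=O)(=O)NCc1ccc2c(c1)S(=O)(=O)C=C(c1c(O)c3cc(F)ccc3n(Cc3ccc(F)cc3)c1=O)N2`) has been tested in an ADME assay on 2209-23 cells (Homo sapiens) for cytotoxicity, read by WST assay (on this read-out lower numbers stand for higher toxicity in this test and higher numbers for lower toxicity in this test), where compound 2 returns only the limit of the assay, > 50000 nM. Its neighbour, compound 1 (`CC(=O)Nc1ccc2c(c1)S(=O)(=O)C=C(c1c(O)c3cc(F)ccc3n(Cc3ccc(F)cc3)c1=O)N2`), likewise gives only a limit; in this assay compound 1 shows > 50000 nM. Among the compounds with values here, the single measured step, a step that the two limits leave unreadable from compound 1 to compound 2, therefore cannot be read in size. Both values sit at the same limit (the limit of > 50000 nM in this assay, at which 2 of the 2 values shown sit). Compound 3 (`CS(=O)(=O)c1ccc2c(c1)S(=O)(=O)C=C(c1c(O)c3cc(F)ccc3n(Cc3ccc(F)cc3)c1=O)N2`) has not yet been measured; it differs from compound 2 by methylsulfonyl in place of (methanesulfonamido)methyl on an aromatic carbon. Within the data shown here, no measured step bears on this change in a readable way, so no step beyond the scatter is expected in this assay. The estimate for compound 3 in this assay is 50000 nM, within 20000 nM to 150000 nM, most likely again reported as a limit. The step expected in this assay, a number no higher from compound 2 to compound 3 (the limit leaves the size open), is accordingly none beyond the scatter.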

Compound 3, half-maximal cytotoxic concentration: > 50000 nM
Compound 3 gave a limit, no number (the forecaster's own chance of this, stated with the estimate: 80%); the middle value sits exactly at the limit.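

In this assay, within the data shown here, compound 3 gives only a limit, so no step among compound 1, compound 2 and compound 3 can be read: the limit of > 50000 nM in this assay, at which 3 of the 3 values shown sit.

Whether methylsulfonyl, acetamido and (methanesulfonamido)methyl differ at all on this read-out stays open, as none of the compounds shown gives a number.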